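The source may report more compounds than this note shows. Statements on the series, on what has been measured and on what is new or still open speak of the compounds shown alone.

Three compounds sharing one core were tested in a functional assay on MCF7 cells (Homo sapiens) for cytotoxicity, read by MTT assay, with a stated time of 96 h; a lower number here means a stronger inhibitor, a higher number a weaker inhibitor. Compound 1 `COc1cc(C(=O)c2cn(-c3cccc(C)c3)cc2-c2ccccc2Cl)cc(OC)c1OC` gives 420 nM. Compound 2 `COc1cc(C(=O)c2cn(-c3cccc(C)c3)cc2-c2ccccc2[N+](=O)[O-])cc(OC)c1OC` differs from it by the change (nitro in place of chloro on an aromatic carbon), and in this assay compound 2 gives 220 nM, so that the step of a 1.9-fold lower number from compound 1 to compound 2 (0.28 log units; within the scatter) is small. Compound 3 `COc1cc(C(=O)c2cn(-c3ccc(C)cc3)cc2-c2ccccc2Cl)cc(OC)c1OC` carries a different group on the ring nitrogen than compound 1, as told by 4-methylphenyl in place of 3-methylphenyl on an aromatic nitrogen; in this assay compound 3 gives 180 nM, and the step of a 2.3-fold lower number from compound 1 to compound 3 (0.37 log units; beyond the scatter) is modest.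

Compound 4 `COc1cc(C(=O)c2cn(-c3ccc(C)cc3)cc2-c2ccccc2[N+](=O)[O-])cc(OC)c1OC` has not yet been measured. It relates to compound 3 exactly as compound 2 relates to compound 1, through the change (nitro in place of chloro on an aromatic carbon), made at a place described in the same words in both pairs, so this is the same change seen once already. Because that earlier step was a 1.9-fold lower number from compound 1 to compound 2 (0.28 log units; within the scatter), the step to compound 4 is expected to be of similar size, a 1.6-fold lower number from compound 3 to compound 4 (0.21 log units; within the scatter), with the caution that it rests on one pair only. For compound 4 in this assay the expected value is 110 nM, estimated to lie between 55 nM and 220 nM.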

Compound 4, half-maximal inhibitory concentration: 65 nM
For compound 4 the middle estimate is 1.7-fold (0.23 log units) above the measured one; low and high end bracket the measured number.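

In this assay, nitro in place of chloro on an aromatic carbon gives a 2.8-fold lower number from compound 3 to compound 4 (0.44 log units; beyond the scatter), and this step agrees with the earlier step for the same change: the same change on two cores in this assay, a 1.9-fold lower number (0.28 log units; within the scatter) from compound 1 to compound 2 and a 2.8-fold lower number (0.44 log units; beyond the scatter) from compound 3 to compound 4, 1.5-fold (0.16 log units) apart, within the scatter of two such steps. Likewise, 4-methylphenyl in place of 3-methylphenyl on an aromatic nitrogen gives a 3.4-fold lower number from compound 2 to compound 4 (0.53 log units; beyond the scatter), which agrees with its own earlier step: the same change on two cores in this assay, a 2.3-fold lower number (0.37 log units; beyond the scatter) from compound 1 to compound 3 and a 3.4-fold lower number (0.53 log units; beyond the scatter) from compound 2 to compound 4, 1.5-fold (0.16 log units) apart, within the scatter of two such steps. Across these four compounds, each change therefore carries over from one core to the other with a similar size, but each comparison rests on just two steps in a single assay, so this does not show that either change would behave the same way on other cores, nor does it explain why the numbers move.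

The compounds shown leave open whether other groups in place of the chloro or nitro, such as an amine or a carboxylic acid, would carry over in the same way. As far as these compounds go, it also remains open what a longer chain in place of the methyl would do on either core.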